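A few compounds are considered here, and "the series" means these few. Any claim that something is new, unique, unknown or untested is made for them only; others in the source may bear on it.

Measured so far:
compound 1, `CCCCNc1nc(-c2ccccc2)c(Cc2c(O)ccc3ccccc23)c(=O)[nH]1`: 24500 nM
compound 2, `CCN(CC)c1nc(-c2ccccc2)c(Cc2c(O)ccc3ccccc23)c(=O)[nH]1`: 15400 nM

In a functional assay on EJ cells (Homo sapiens) for antiproliferative activity, read by MTT assay, with a stated time of 3 h (on this read-out lower numbers stand for stronger inhibition and higher numbers for weaker inhibition), compound 1 gives 24500 nM and compound 2 gives 15400 nM. Compound 2 carries the smallest of the two numbers, yet a 1.6-fold lower number from compound 1 to compound 2 (0.20 log units; within the scatter) is within the scatter, so the two do not separate. Compound 3 `C#CCNc1nc(-c2ccccc2)c(Cc2c(O)ccc3ccccc23)c(=O)[nH]1` differs by propargylamino in place of diethylamino on an aromatic carbon. Among the compounds with values here, the only measured step that bears on it is a 1.6-fold lower number from compound 1 to compound 2 (0.20 log units; within the scatter), likewise an exchange of the amino substituent on the same aromatic carbon, and it stayed within the scatter. For compound 3 the expected step is a 1.2-fold higher number from compound 2 to compound 3 (0.07 log units; within the scatter), none beyond the scatter. Compound 3 is estimated at 18000 nM, within 8000 nM to 40000 nM.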

Compound 3, half-maximal inhibitory concentration: 16800 nM
The estimate for compound 3 lay 1.1-fold (0.03 log units) above the measured number, and the stated range covers the measured number.
By their numbers in this assay, from the lowest: compounds 2, 3 and 1 (each within the scatter of the next).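

At the aromatic carbon between two ring nitrogen atoms, propargylamino in this assay gives a 1.1-fold higher number from compound 2 to compound 3 (0.04 log units; within the scatter) and a 1.5-fold lower number from compound 1 to compound 3 (0.16 log units; within the scatter), so the series now holds three amino substituents that do not separate. A triple bond and the hydrogen-bond donor that diethylamino lacks both enter here, and the step stays within the scatter. No evidence bears on this result.

Still open, from the compounds shown here alone, is whether a morpholine ring or a longer chain ending in a carboxylic acid at this carbon would give a step beyond the scatter.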